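The source may hold more compounds than are shown below. What is called first, only, known or untested is meant among the compounds shown, and "the series" means these compounds.

Measured so far in a functional assay (Pituitary gland cell) with Rattus norvegicus as the target; a lower number here means that less compound is needed, a higher number that more compound is needed for the effect:
- compound 1 `Cc1ccccc1-c1ccc(CN2C(=O)[C@H](NC(=O)CC(C)(C)N)CCc3ccccc32)cc1` gives 1 uM
- compound 2 `CC(O)Cn1nnc(-c2ccccc2-c2ccc(CN3C(=O)[C@H](NC(=O)CC(C)(C)N)CCc4ccccc43)cc2)n1` gives 0.05 uM
- compound 3 `COC(=O)c1ccccc1-c1ccc(CN2C(=O)[C@H](NC(=O)CC(C)(C)N)CCc3ccccc32)cc1` gives 2 uM

Compound 3 stands highest of the three numbers in this assay. Its nearest neighbour is compound 1, a 2.0-fold higher number from compound 1 to compound 3 (0.30 log units; within the scatter), a gap within the scatter; its furthest is compound 2, a 40-fold higher number from compound 2 to compound 3 (1.60 log units; beyond the scatter), well beyond it.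

Compound 4 `CC(C)(N)CC(=O)N[C@@H]1CCc2ccccc2N(Cc2ccc(-c3ccccc3S(=O)(=O)NC(=O)c3ccccc3)cc2)C1=O` is the next candidate. It differs from compound 3 in one place: benzoylsulfamoyl in place of methoxycarbonyl on an aromatic carbon

Within the data shown here, two measured steps bear on this. From compound 1 to compound 2, a larger group carrying a hydrogen-bond donor replaced methyl on the same aromatic carbon, and the result was a 20-fold lower number from compound 1 to compound 2 (1.30 log units; beyond the scatter). Going the other way, a 40-fold higher number from compound 2 to compound 3 (1.60 log units; beyond the scatter), so the methoxycarbonyl of compound 3 sits at the unfavourable end of the range seen so far. Benzoylsulfamoyl is again a large group with one hydrogen-bond donor entering at that carbon, so a step in the same direction as from compound 1 to compound 2 is expected, though the entering group is not the same and the size is uncertain.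

For compound 4 the expected step is a 20-fold lower number from compound 3 to compound 4 (1.30 log units; beyond the scatter), giving an estimated 0.1 uM in this assay, with a range from 0.02 uM to 0.6 uM.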

Compound 4, concentration for half-maximal effect: 3 uM
Compound 4: the middle estimate sits 30-fold (1.48 log units) below what was measured; measured number above the stated range.
By their numbers in this assay, from the lowest: compound 2; then compounds 1, 3 and 4 (each within the scatter of the next, the first and the last beyond it).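

In this assay, a large group with a hydrogen-bond donor on this aromatic carbon, ortho to a large group, does not by itself reproduce the result of 2-(2-hydroxypropyl)-2H-tetrazol-5-yl: benzoylsulfamoyl in place of methoxycarbonyl gives a 1.5-fold higher number from compound 3 to compound 4 (0.18 log units; within the scatter), while in place of the tetrazolyl group it gives a 60-fold higher number from compound 2 to compound 4 (1.78 log units; beyond the scatter). Set against methyl, the same group gives a 3.0-fold higher number from compound 1 to compound 4 (0.48 log units; beyond the scatter), so of the four groups at this position only the one in compound 2 stands apart. No measurement is available that accounts for the gap between the two large groups.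

The compounds shown leave open whether the low number of compound 2 rests on the tetrazolyl part or on its 2-hydroxypropyl chain. A bare tetrazolyl group or a carboxylic acid on this carbon would help to separate the two.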